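Series notes: urea biaryls at the melanin-concentrating hormone receptor

This account rests on a few compounds, and the source may have more. Where it says the series, first, only, none or still open, it means among the compounds named here.

The set holds one measured number and one limit in an in vitro functional assay on HEK293 cells for antagonist activity at melanin-concentrating hormone receptor 1 (Homo sapiens), read by GTPgammaS binding, with a stated time of 45 min; a higher number here means a more potent compound, by a factor of ten per unit of this negative logarithm, a lower number a less potent compound. Compound 1 `Cc1ccc(CN2CCC(NC(=O)NCc3ccc(-c4cccc(C#N)c4)cc3)CC2)cc1` carries the 3-cyanophenyl biaryl on a urea whose second nitrogen still bears its hydrogen; in this assay compound 1 gives 6.39. Compound 2 `COc1ccc(-c2ccc(CN(CC(=O)C(C)(C)O)C(=O)NC3CCN(Cc4ccc(C)cc4)CC3)cc2)cc1` replaces that urea hydrogen with the hydroxy-ketone chain and carries a 4-methoxyphenyl biaryl instead. For compound 2 the assay reports only a limit, < 5, which is the point at which one of the two values shown sits (the limit of < 5 in this assay, at which 1 of the 2 values shown sits). Compound 3 `Cc1ccc(CN2CCC(NC(=O)N(CC(=O)C(C)(C)O)Cc3ccc(-c4cccc(C#N)c4)cc3)CC2)cc1` keeps the chain of compound 2 and differs from it in a single place: 3-cyanophenyl in place of 4-methoxyphenyl on an aromatic carbon. Going by the values given here, no measured pair shows this swap alone, so the size of the step is open; compound 1 shows that the 3-cyanophenyl biaryl can sit in a compound with a real number, but compound 1 lacks the chain. The expected change in this assay is a modest rise, a number at least 0.30 log units higher from compound 2 to compound 3 (that floor lies within the scatter). Compound 3 is estimated at 5.3, in the range 4.7 to 6.2, with a fair chance that only a limit returns again.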

Compound 3, negative logarithm of the antagonist equilibrium constant: 5.3
For compound 3 middle estimate and measured number coincide at the digits printed; the range from low to high includes it.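

With the 3-cyanophenyl biaryl held fixed, ((1-hydroxy-1-methylethyl)carbonyl)methyl in place of hydrogen on the amide-type nitrogen now has a measured price in this assay, giving a number 1.09 log units lower from compound 1 to compound 3 (beyond the scatter), although compound 3 still returns a number and not a limit. At the aromatic carbon para to a large group, with the chain present, 3-cyanophenyl in place of 4-methoxyphenyl gives a number at least 0.30 log units higher from compound 2 to compound 3 (that floor lies within the scatter), so this swap can be read only as a floor and not as a full step. Compound 2 remains a limit and not a number: the limit of < 5 in this assay, at which 1 of the 3 values shown sits.

The true size of the biaryl swap stays open, and nothing shown separates the contribution of the hydroxyl in the chain from that of its ketone carbonyl. Also open, going by these compounds, is whether a plain methyl on the same nitrogen, or a chain ending in a carboxylic acid or an amine, would stay closer to the level of compound 1 in this assay, where compound 1 gives 6.39.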